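Para-hydroxyphenyl ethylidene hydrazone on a triazolopyrimidine core

A few compounds are considered here, and "the series" means these few. Any claim that something is new, unique, unknown or untested is made for them only; others in the source may bear on it.

Measured so far:
compound 1 `CCCSc1nc(N/N=C/c2ccccc2Cl)c2nnn(Cc3ccccc3)c2n1` gives 6180 nM in a functional assay on ECa-109 cells (Homo sapiens) for antiproliferative activity, read by MTT assay, with a stated time of 72 h; a lower number here means a stronger inhibitor, a higher number a weaker inhibitor;
compound 2 `CCCSc1nc(N/N=C/c2ccc(N(C)C)cc2)c2nnn(Cc3ccccc3)c2n1` gives 20000 nM;
compound 3 `CCCSc1nc(N/N=C(\C)c2ccccc2O)c2nnn(Cc3cccc(Cl)c3)c2n1` gives 13000 nM.

Compound 1 gives the lowest number of the three, with compound 3 the nearest and compound 2 the furthest; both gaps lie beyond the scatter. For the measured compounds named here, the only single-place step known runs from compound 1 to compound 2, a 4-(dimethylamino)phenyl in place of 2-chlorophenyl on the carbon with a double bond to nitrogen, and there the number moved by a 3.2-fold higher number from compound 1 to compound 2 (0.51 log units; beyond the scatter).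

Compound 4 `CCCSc1nc(N/N=C(\C)c2ccc(O)cc2)c2nnn(Cc3ccccc3)c2n1` differs from compound 1 as follows: a group of 10 heavy atoms (8 carbon, 1 nitrogen, 1 oxygen; one six-membered aromatic ring of carbon only) in place of a group of 9 heavy atoms (7 carbon, 1 nitrogen, 1 chlorine; one six-membered aromatic ring of carbon only), on a nitrogen on an aromatic ring. Going by the values given here, no measured pair shows this exact exchange. Compound 3 shows a hydroxyphenyl ethylidene hydrazone, but on a different benzyl group, so its value only hints that such arms stay in the same broad range. Among the compounds with values here, because the one comparable step a 3.2-fold higher number from compound 1 to compound 2 (0.51 log units; beyond the scatter) weakened the number, a modest weakening is expected here too, with wide uncertainty.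

The estimate for compound 4 is therefore 12000 nM, within 5000 nM to 30000 nM, a step of a 1.9-fold higher number from compound 1 to compound 4 (0.29 log units; within the scatter).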

Compound 4, half-maximal inhibitory concentration: 32500 nM
The estimate for compound 4 lay 2.7-fold (0.43 log units) below the measured number; measured number outside the range, above it.
By their numbers in this assay, from the lowest: compound 1; then compounds 3, 2 and 4 (each within the scatter of the next, the first and the last beyond it).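

In this assay, replacing the arm of compound 1 with the hydroxyphenyl-bearing group of compound 4 gives a 5.3-fold higher number from compound 1 to compound 4 (0.72 log units; beyond the scatter), so a second, quite different group on this nitrogen also moves away from the low number that compound 1 holds. The earlier step had shown this for only one replacement, and compound 2 at 20000 nM and compound 4 at 32500 nM now lie within the scatter of each other, so these two groups cannot be ranked even though they differ in their counts of atoms, donors and acceptors. No measured evidence on any property of these groups is at hand to account for the rise.

The exchange from compound 1 to compound 4 removes the chlorine, brings in oxygen and adds a carbon all at once, and the compounds shown do not separate these changes from one another. Also open, as far as these compounds go, is how this arm would respond to an amine or a carboxylic acid on its aromatic ring, or to a plain unsubstituted phenyl, and whether any such group could match or pass the number of compound 1.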